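The source may report more compounds than this note shows. Statements on the series, on what has been measured and on what is new or still open speak of the compounds shown alone.

Three compounds share one core and differ only in the aryl group on the five-membered ring. Compound 1 `COc1cccc(-c2c(C)nn(-c3nc(-c4ccc(Cl)c(Cl)c4)c(SC(C)C)s3)c2C(=O)O)c1` gives 14000 nM in a functional assay on BJAB cells (Homo sapiens) for antiproliferative activity, with a stated time of 4 days; on this read-out higher numbers stand for an effect only at larger amounts of compound and lower numbers for an effect already at smaller amounts. Compound 2 `COc1ccc(-c2c(C)nn(-c3nc(-c4ccc(Cl)c(Cl)c4)c(SC(C)C)s3)c2C(=O)O)cc1` gives 2100 nM in this assay, the lowest of the three numbers. Compound 3 `Cc1ccccc1-c1c(C)nn(-c2nc(-c3ccc(Cl)c(Cl)c3)c(SC(C)C)s2)c1C(=O)O` gives 5500 nM in this assay. The steps among them are modest and beyond the scatter: a 6.7-fold lower number from compound 1 to compound 2 (0.82 log units; beyond the scatter), a 2.5-fold lower number from compound 1 to compound 3 (0.41 log units; beyond the scatter), and a 2.6-fold higher number from compound 2 to compound 3 (0.42 log units; beyond the scatter). Compound 4 `Cc1nn(-c2nc(-c3ccc(Cl)c(Cl)c3)c(SC(C)C)s2)c(C(=O)O)c1-c1ccncc1` has not yet been measured; its change from compound 2 is pyridin-4-yl in place of 4-methoxyphenyl on an aromatic carbon. For the measured compounds named here, none of the measured steps brings in a ring with a hetero atom, so they bear only loosely on this change; what they show is that exchanging one aryl group for another has moved the number by modest amounts in both directions, and that compound 2, with its 2100 nM, sits at the favourable end. A modest move towards a higher number is therefore expected, a 2.1-fold higher number from compound 2 to compound 4 (0.33 log units; beyond the scatter). Compound 4 is estimated at 4500 nM in this assay, with a range from 1500 nM to 14000 nM.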

Compound 4, half-maximal effective concentration: 5900 nM
Compound 4: middle estimate off by 1.3-fold (0.12 log units), on the low side; low and high end bracket the measured number.
By their numbers in this assay, from the lowest: compound 2; then compounds 3 and 4 (each within the scatter of the next); then compound 1.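

In this assay, for the compounds shown here, the pyridin-4-yl group brings a ring with a hetero atom to this position for the first time, and it does not match the 4-methoxyphenyl group (a 2.8-fold higher number from compound 2 to compound 4 (0.45 log units; beyond the scatter)). Against the 2-methylphenyl group, the change stays within the scatter (a 1.1-fold higher number from compound 3 to compound 4 (0.03 log units; within the scatter)), whereas against the 3-methoxyphenyl group it gives a modest step in the favourable direction (a 2.4-fold lower number from compound 1 to compound 4 (0.38 log units; beyond the scatter)). Among these four compounds, the ring nitrogen therefore leaves the number within the modest span set by the carbon-only aryl groups, and compound 2 remains lowest, with its steps to all three others beyond the scatter.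

From the compounds shown here alone, how pyridin-3-yl or an aminophenyl group would compare at this position stays open. Nothing at hand explains why these numbers differ.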